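The compounds below may be only part of what the source reports. "The series", "measured", "known", "first", "only" and "open" are said of these compounds alone.

Measured compounds:
compound 1, `C[C@H](NC(=O)C(=O)NCc1ccc(Cl)cc1)C(=O)N[C@@H](CC(=O)O)C(=O)COc1c(F)c(F)cc(F)c1F`, giving 8.4 nM
compound 2, `C[C@H](NC(=O)C(=O)NCCC1CCCC1)C(=O)N[C@@H](CC(=O)O)C(=O)COc1c(F)c(F)cc(F)c1F`, giving 11 nM
compound 3, `Cc1ccc(CNC(=O)C(=O)N[C@@H](C)C(=O)N[C@@H](CC(=O)O)C(=O)COc2c(F)c(F)cc(F)c2F)cc1`, giving 50 nM

In a functional assay on Jurkat cells (Homo sapiens) (a lower number here means a stronger inhibitor, a higher number a weaker inhibitor), compound 3 stands highest of the three numbers, its nearest neighbour being compound 2 and the furthest compound 1. Compound 4, `C[C@H](NC(=O)C(=O)NCc1ccc(Cl)cc1Cl)C(=O)N[C@@H](CC(=O)O)C(=O)COc1c(F)c(F)cc(F)c1F`, differs from compound 3 by 2,4-dichlorophenyl in place of 4-methylphenyl on a saturated chain carbon bound to an amide-type nitrogen. For the measured compounds named here, the one measured step that bears on this change is a 6.0-fold higher number from compound 1 to compound 3 (0.77 log units; beyond the scatter), which compares a chloro with a methyl on the same aromatic carbon; read in reverse it points to a lower number when chloro replaces methyl. Going by the values given here, the second chloro has no precedent among the measured compounds. Compound 4 is therefore expected to show a step of about a 5.6-fold lower number from compound 3 to compound 4 (0.74 log units; beyond the scatter). The value for compound 4 is estimated at 9 nM, within a range of 3.5 nM to 25 nM.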

Compound 4, half-maximal inhibitory concentration: 165 nM
For compound 4 the middle estimate is 18-fold (1.26 log units) below the measured one; measured number outside the range, above it.
By their numbers in this assay, from the lowest: compounds 1 and 2 (each within the scatter of the next); then compound 3; then compound 4.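

In this assay, adding a second chloro to the ring of compound 1 does not add to the first but costs heavily: chloro in place of hydrogen on an aromatic carbon gives a large loss (a 20-fold higher number from compound 1 to compound 4 (1.29 log units; beyond the scatter)). At this position 2,4-dichlorophenyl also falls behind both 4-methylphenyl (a 3.3-fold higher number from compound 3 to compound 4 (0.52 log units; beyond the scatter)) and cyclopentylmethyl (a 15-fold higher number from compound 2 to compound 4 (1.18 log units; beyond the scatter)), so a chloro that helps in compound 1 does not help when a second one joins it. No measurement shown gives a reason for this loss. Going by these compounds, whether a fluoro or a methoxy in place of the added chloro would bring the same loss stays open.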